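Aryl chlorine position change on the shared core

The source may report more compounds than this note shows. Statements on the series, on what has been measured and on what is new or still open speak of the compounds shown alone.

Measured compounds:
compound 1 `OC(CCn1nc2c(Br)c(Br)c(Br)c(Br)c2n1)c1cccc(Cl)c1` — 101%
compound 2 `C[C@@H](O)CCn1nc2c(Br)c(Br)c(Br)c(Br)c2n1` — 77%
compound 3 `C[C@H](O)CCn1nc2c(Br)c(Br)c(Br)c(Br)c2n1` — 89%

In a functional assay on MCF7 cells (Homo sapiens) for antiproliferative activity, read by MTT assay, with a stated time of 48 h, tested at 25 uM (on this read-out lower numbers stand for a stronger effect and higher numbers for a weaker effect at the one concentration tested), compound 1 stands highest of the three numbers, that is weakest on this read-out; compound 3 lies below it beyond the scatter and compound 2 further still. Within the data shown here, the only measured step, a number 12 percentage points higher from compound 2 to compound 3 (beyond the scatter), rests on the fact that compounds 2 and 3 differ only in the configuration as drawn and involves no change of the aryl group.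

Compound 4 `OC(CCn1nc2c(Br)c(Br)c(Br)c(Br)c2n1)c1ccc(Cl)cc1` differs from compound 1 by 4-chlorophenyl in place of 3-chlorophenyl on a saturated chain carbon bound to an oxygen on a saturated carbon and a saturated chain carbon. Among the measured compounds shown here, no measured step bears on this change, so no step beyond the scatter is expected; the expected step is a number 5 percentage points lower from compound 1 to compound 4 (within the scatter). For compound 4 the estimated value in this assay is 96%, in the range 78% to 110%.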

Compound 4, a percentage reported as activity, at one concentration (the size of the read-out at that concentration, not a potency): 92%
The estimate for compound 4 lay 4 percentage points above the measured number; low and high end bracket the measured number.
By their numbers in this assay, from the lowest: compound 2; then compounds 3, 4 and 1 (each within the scatter of the next, the first and the last beyond it).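

In this assay, among these compounds, 4-chlorophenyl in place of 3-chlorophenyl gives a number 9 percentage points lower from compound 1 to compound 4 (within the scatter), the first measured step on the aryl group. The two chlorophenyl isomers are therefore not separated on this read-out, so chlorine placement on this ring does not distinguish them here. No available fact bears on this step, as the only one concerns configuration in a different pair. As far as these compounds go, it remains open whether an unsubstituted phenyl or a 2-chlorophenyl group would give a step beyond the scatter at this carbon. From the compounds shown here alone, an amine or a carboxylic acid in place of the hydroxyl also remains open.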